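Chloro addition on the pyridinyl amide of compound 3

The compounds below may be only part of what the source reports. "The series", "measured", "known", "first", "only" and "open" are said of these compounds alone.

Compound 1 `CN1C[C@H](C(=O)Nc2ccccc2)[C@@H](c2ccc(/C=C/C(=O)Nc3ccccc3N)cc2)C1` gives 7 mL/min/kg in an in vitro ADME assay on microsomes from liver (Homo sapiens) for pharmacokinetics, read by LC-MS, with a stated time of 10 min, tested at 1 uM; a lower number here means slower removal, a higher number faster removal of the compound. Compound 2 `CN1C[C@H](C(=O)Nc2cccc(Cl)c2)[C@@H](c2ccc(/C=C/C(=O)Nc3ccccc3N)cc2)C1` differs by chloro in place of hydrogen on an aromatic carbon and gives 7 mL/min/kg; the step is no change at the digits printed from compound 1 to compound 2 (within the scatter). Compound 3 `CN1C[C@H](C(=O)Nc2ccccn2)[C@@H](c2ccc(/C=C/C(=O)Nc3ccccc3N)cc2)C1` differs from compound 1 by pyridin-2-yl in place of phenyl on an amide-type nitrogen; compound 3 gives 8 mL/min/kg. Compound 4 `CN1C[C@H](C(=O)Nc2ccc(Cl)cn2)[C@@H](c2ccc(/C=C/C(=O)Nc3ccccc3N)cc2)C1` differs from compound 3 by chloro in place of hydrogen on an aromatic carbon. This is the same kind of change as that from compound 1 to compound 2, but the place differs: there it sits on an aromatic carbon of a six-membered aromatic ring of carbon only, meta to a large group; here on an aromatic carbon of a six-membered aromatic ring with 1 nitrogen, two atoms from the ring nitrogen, para to a large group. Because no change at the digits printed from compound 1 to compound 2 (within the scatter) stayed within the scatter, the step from compound 3 to compound 4 is expected to be no change at the digits printed from compound 3 to compound 4 (within the scatter). Compound 4 is thus estimated at 8 mL/min/kg, between 5 mL/min/kg and 14 mL/min/kg.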

Compound 4, clearance: 13 mL/min/kg
Compound 4: middle estimate off by 1.6-fold (0.21 log units), on the low side, and the stated range covers the measured number.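

In this assay, chloro in place of hydrogen on the pyridin-2-yl amide gives a 1.6-fold higher number from compound 3 to compound 4 (0.21 log units; within the scatter), and the wider comparisons read a 1.9-fold higher number from compound 2 to compound 4 (0.27 log units; within the scatter) and a 1.9-fold higher number from compound 1 to compound 4 (0.27 log units; within the scatter). The change carries between the two cores with no difference that can be told apart in this read-out: the same change on two cores in this assay, no change at the digits printed (within the scatter) from compound 1 to compound 2 and a 1.6-fold higher number (0.21 log units; within the scatter) from compound 3 to compound 4, 1.6-fold (0.21 log units) apart, within the scatter of two such steps. This rests on a single pair of steps, with chloro at one place on each ring, so it does not show that chloro would behave the same way at other places or on other cores.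

Still open, as far as these compounds go, is whether a different group at the same place, such as methoxy, a nitrile or a carboxylic acid, would also carry from one core to the other.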